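Urea-to-amide step on the shared core, single-point growth readout

The source may report more compounds than this note shows. Statements on the series, on what has been measured and on what is new or still open speak of the compounds shown alone.

Measured so far:
compound 1, `COc1cc(Cl)cc(-c2nn(-c3cccc(NC(=O)Nc4ccc(Cl)c(C(F)(F)F)c4)c3)cc2-c2ccncc2)c1`, 96%
compound 2, `COc1cc(Cl)cc(-c2nn(-c3cccc(NC(=O)Nc4cccc(C(F)(F)F)c4)c3)cc2-c2ccncc2)c1`, 100%

In a functional assay on SF-539 cells (Homo sapiens) for inhibition, read by sulforhodamine B assay, with a stated time of 48 h, tested at 0.01 uM (a lower number here means a stronger effect, a higher number a weaker effect of the compound at the concentration tested), compound 2 gives 100%, the highest of the two numbers; its nearest neighbour is compound 1 with 96%, and the step of a number 4 percentage points higher from compound 1 to compound 2 (within the scatter) lies within the scatter, so the two compounds are not distinguishable here.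

Compound 3, `COc1cc(Cl)cc(-c2nn(-c3cccc(NC(=O)c4cccc(C(F)(F)F)c4)c3)cc2-c2ccncc2)c1`, is not yet measured. It differs from compound 2 by 3-(trifluoromethyl)phenyl in place of (3-(trifluoromethyl)phenyl)amino on a carbonyl carbon, the change sitting on a carbonyl carbon whose other neighbours are an amide-type nitrogen. Among the measured compounds shown here, no measured step touches this part of the molecule; the single step from compound 1 to compound 2 concerns a chloro elsewhere and was within the scatter. With both measured compounds near full activity in this assay, no shift beyond the scatter is expected for compound 3, and its value is estimated at 98% (range 86% to 110%), a step of a number 2 percentage points lower from compound 2 to compound 3 (within the scatter).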

Compound 3, a percentage reported as activity, at one concentration (the size of the read-out at that concentration, not a potency): 93%
Compound 3: middle estimate off by 5 percentage points, on the high side, and the stated range covers the measured number.
By their numbers in this assay, from the lowest: compounds 3, 1 and 2 (each within the scatter of the next).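

In this assay, the urea-to-amide change on the carbonyl carbon gives a number 7 percentage points lower from compound 2 to compound 3 (within the scatter) and, with the chloro-bearing urea as the starting point, a number 3 percentage points lower from compound 1 to compound 3 (within the scatter) as well. Among the compounds shown here, this is the first reading at this position: (3-(trifluoromethyl)phenyl)amino and (4-chloro-3-(trifluoromethyl)phenyl)amino can each give way to 3-(trifluoromethyl)phenyl, losing the nitrogen and its hydrogen-bond donor, without a step beyond the scatter at this single concentration. Nothing available bears on the reason for this result.

Because all three compounds sit close together at one concentration, the read-out leaves open whether urea and amide would separate at concentrations where growth is clearly inhibited. Also open, as far as these compounds go, is whether a sulfonamide on the same nitrogen, or a morpholine ring in place of the 3-(trifluoromethyl)phenyl group, would move the number beyond the scatter.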